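This account rests on a few compounds, and the source may have more. Where it says the series, first, only, none or still open, it means among the compounds named here.

Compound 1, `CCCCOC1=C(C(=O)c2ccccc2)C(c2ccc(Br)cc2)N(CCCn2ccnc2)C1=O`, in a functional assay on NCI-H1299 cells (Homo sapiens) for antiproliferative activity, read by MTT assay, with a stated time of 72 h (on this read-out lower numbers stand for stronger inhibition and higher numbers for weaker inhibition), compound 1 gives 17100 nM.
Compound 2, `CCOc1ccc(NC2=C(C(=O)c3ccccc3)C(c3ccc(Br)cc3)N(CCCn3ccnc3)C2=O)cc1`, in this assay compound 2 gives 20000 nM.

Among these two numbers compound 2 carries the higher one, but its only neighbour is compound 1, and the step of a 1.2-fold higher number from compound 1 to compound 2 (0.07 log units; within the scatter) falls within the scatter, so the two cannot be told apart. That single step replaced butoxy with (4-ethoxyphenyl)amino on a double-bonded ring carbon and left the number essentially unchanged.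

Compound 3, `O=C(C1=C(Nc2ccccc2Br)C(=O)N(CCCn2ccnc2)C1c1ccc(Br)cc1)c1ccccc1`, has not yet been measured. It differs from compound 2 in one place: 2-bromophenyl in place of 4-ethoxyphenyl on an amine nitrogen. Going by the values given here, no measured step alters the group on the amine nitrogen, so the only guide is that the one change made so far at this side of the shared core did nothing beyond the scatter. On that basis no step beyond the scatter is expected, no change at the digits printed from compound 2 to compound 3 (within the scatter). Compound 3 is therefore estimated at 20000 nM, with a range from 8000 nM to 50000 nM.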

Compound 3, half-maximal inhibitory concentration: 15600 nM
For compound 3 the middle estimate is 1.3-fold (0.11 log units) above the measured one; low and high end bracket the measured number.
By their numbers in this assay, from the lowest: compounds 3, 1 and 2 (each within the scatter of the next).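

On the amine nitrogen, two different aryl groups can now be compared directly: this assay shows a 1.3-fold lower number from compound 2 to compound 3 (0.11 log units; within the scatter), so 2-bromophenyl and 4-ethoxyphenyl cannot be told apart here, even though one carries a bromine and the other an ethoxy group. Set against butoxy on the double-bonded ring carbon, (2-bromophenyl)amino gives a 1.1-fold lower number from compound 1 to compound 3 (0.04 log units; within the scatter), so all three groups compared at this place lie within the scatter of one another. No measurement on hand offers an explanation for this flat result.

As far as these compounds go, it remains open whether a simple amine, a hydroxyl or a carboxylic acid at this place would move the number beyond the scatter. Also open, from the compounds shown here alone, is what a change elsewhere on the shared core would do.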